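Swapping fluorine for methyl at the acid-bearing carbon

A few compounds are considered here, and "the series" means these few. Any claim that something is new, unique, unknown or untested is made for them only; others in the source may bear on it.

Three compounds share one core and differ only at the carbon that carries the acid. Compound 1 `COc1ccc(F)c([C@H]2CC[C@H](COc3cccc([C@H](C4CC4)[C@H](C)C(=O)O)c3)CC2)c1` gives 2 nM in a functional assay on cells for agonist activity at Free fatty acid receptor 1 (Homo sapiens), read by HTRF and inositol phosphate accumulation, with a stated time of 90 min; on this read-out higher numbers stand for an effect only at larger amounts of compound and lower numbers for an effect already at smaller amounts. Compound 2 `COc1ccc(F)c([C@H]2CC[C@H](COc3cccc([C@H](C4CC4)[C@@H](F)C(=O)O)c3)CC2)c1` gives 20 nM, and compound 3 `COc1ccc(F)c([C@H]2CC[C@H](COc3cccc([C@H](C4CC4)[C@](C)(F)C(=O)O)c3)CC2)c1` gives 89 nM, the highest of the three numbers. The steps among them are all beyond the scatter: a 10-fold higher number from compound 1 to compound 2 (1.00 log units; beyond the scatter), a 45-fold higher number from compound 1 to compound 3 (1.65 log units; beyond the scatter) and a 4.5-fold higher number from compound 2 to compound 3 (0.65 log units; beyond the scatter).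

Compound 4 `COc1ccc(F)c([C@H]2CC[C@H](COc3cccc([C@H](C4CC4)C(C)(C)C(=O)O)c3)CC2)c1` is not yet measured. The change from compound 3 is 1-carboxy-1-methylethyl in place of 1-carboxy-1-fluoroethyl on a saturated chain carbon bound to an aromatic carbon and a saturated ring carbon. Among the compounds with values here, no measured step removes a fluorine from this carbon while keeping a methyl there, so the closest guide is that a fluorine in place of a methyl cost a 10-fold higher number from compound 1 to compound 2 (1.00 log units; beyond the scatter), and that placing a fluorine onto the methyl-bearing carbon cost a 45-fold higher number from compound 1 to compound 3 (1.65 log units; beyond the scatter). Reversing such a fluorine for a methyl is therefore expected to lower the number, though a second methyl has no precedent here. Compound 4 is estimated at 15 nM, with a range from 4 nM to 60 nM, which means an expected step of a 5.9-fold lower number from compound 3 to compound 4 (0.77 log units; beyond the scatter).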

Compound 4, half-maximal effective concentration: 220 nM
Compound 4: middle estimate off by 15-fold (1.17 log units), on the low side; the measured number lies above the stated range.
By their numbers in this assay, from the lowest: compound 1; then compound 2; then compound 3; then compound 4.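

Swapping the fluorine of 1-carboxy-1-fluoroethyl for a methyl does not win back what compound 3 lost in this assay: the number rises further, with a 2.5-fold higher number from compound 3 to compound 4 (0.39 log units; beyond the scatter) as the step. So the fluorine alone does not account for the loss, since 1-carboxy-1-methylethyl carries no fluorine at all and still gives a 110-fold higher number from compound 1 to compound 4 (2.04 log units; beyond the scatter) and an 11-fold higher number from compound 2 to compound 4 (1.04 log units; beyond the scatter) as its steps. Among these four compounds, the two with two groups besides the acid on that carbon, compound 3 and compound 4, have the highest numbers, and the all-carbon version is the higher of the pair.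

Nothing shown here gives a reason for these steps. Going by these compounds, how a hydroxyl or an ethyl group in place of the methyl of compound 1 would behave remains open.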